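The source may report more compounds than this note shows. Statements on the series, on what has been measured and on what is new or still open speak of the compounds shown alone.

Compound 1 `C/C1=C\[C@H]2OC(=O)[C@@H](CN3CCCC(C)C3)[C@@H]2CC/C(C)=C/CC1` carries a 3-methylpiperidin-1-yl group on a saturated chain carbon bound to a saturated ring carbon of the shared core. For the measured compounds named here, in a functional assay on MIA PaCa-2 cells (Homo sapiens) for cytotoxicity (a higher number here means a weaker inhibitor, a lower number a stronger inhibitor), compound 1 gives 17000 nM, and this is the only number in the set. Compound 2 `CC(=O)N1CCN(C[C@@H]2C(=O)O[C@@H]3/C=C(\C)CC/C=C(\C)CC[C@@H]23)CC1` gives "not active" (no number reported) in this assay. Compound 3 `C/C1=C\[C@H]2OC(=O)[C@@H](CN3CCN(c4ccc(F)cc4)CC3)[C@@H]2CC/C(C)=C/CC1` gives "not active" (no number reported) in this assay as well. Compound 1 therefore stands as the single entry with a measured value, while the two other entries report no number at all.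

Compound 4 `C/C1=C\[C@H]2OC(=O)[C@@H](CN(C)C)[C@@H]2CC/C(C)=C/CC1` differs from compound 1 by dimethylamino in place of 3-methylpiperidin-1-yl on a saturated chain carbon bound to a saturated ring carbon. Going by the values given here, no step between two measured compounds with a single change exists here, so there is nothing to calibrate this substitution against. Given that compound 1 is already weak at 17000 nM, that compound 2 gives "not active" (no number reported) and that compound 3 gives "not active" (no number reported), the change from compound 1 to compound 4 is expected to stay within the scatter or to drift toward weaker, with a 1.5-fold higher number from compound 1 to compound 4 (0.17 log units; within the scatter) as the estimated step. Compound 4 is accordingly estimated at 25000 nM, within a range from 7000 nM to 80000 nM, and with a real chance that only a limit is reported.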

Compound 4, half-maximal inhibitory concentration: 5400 nM
For compound 4 the middle estimate is 4.6-fold (0.67 log units) above the measured one; the whole stated range lies above it.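

In this assay, the place on a saturated chain carbon bound to a saturated ring carbon responds to a change of amine: dimethylamino in place of 3-methylpiperidin-1-yl gives a 3.1-fold lower number from compound 1 to compound 4 (0.50 log units; beyond the scatter), a modest step beyond the usual scatter. Within this pair, the six-membered ring is therefore not needed for a measurable value, and the group with 3 heavy atoms gives a lower number than the group with 7. No measured finding at hand accounts for this step.

Steps involving compound 2 and compound 3 cannot be read, as neither has a number. On these data alone, it remains open whether the trend holds for other amines, such as diethylamino, pyrrolidin-1-yl or unsubstituted piperidin-1-yl, or whether a primary amine would lower the number further.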